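Cytotoxicity notes on a substituted-phenyl amide series

A few compounds are considered here, and "the series" means these few. Any claim that something is new, unique, unknown or untested is made for them only; others in the source may bear on it.

Measured compounds:
compound 1, `COc1cc2c(Oc3ccc(NC(=O)c4cc(-c5ccccc5)ccn4)cc3F)ccnc2cc1OCCCN1CCN(C)CC1`: 1010 nM
compound 2, `COc1cc2c(Oc3ccc(NC(=O)c4cc(-c5ccc(F)cc5)ccn4)cc3F)ccnc2cc1OCCCN1CCCCC1`: 12500 nM
compound 3, `COc1cc2c(Oc3ccc(NC(=O)c4cc(-c5ccccc5F)ccn4)cc3F)ccnc2cc1OCCCN1CCCCC1`: "not determined" (no result reported)

In a functional assay on U-87MG ATCC cells (Homo sapiens) for cytotoxicity, read by MTT assay, with a stated time of 72 h (on this read-out higher numbers stand for weaker inhibition and lower numbers for stronger inhibition), compound 1 gives 1010 nM, the lowest of the two numbers on hand. Compound 2 gives 12500 nM, a higher number, and that gap lies beyond the scatter; compound 2 differs from compound 1 at more than one place, so no single change can be read from it. For compound 3 no number was reported in this assay; it too differs from compound 1 at several places.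

Compound 4, `COc1cc2c(Oc3ccc(NC(=O)c4cc(-c5ccccc5C)ccn4)cc3F)ccnc2cc1OCCCN1CCN(C)CC1`, is the only pairing that differs from compound 1 in one place: methyl in place of hydrogen on an aromatic carbon. For the measured compounds named here, no step between measured compounds covers such a change, and nothing among the measured compounds points to a particular direction. The working expectation is a step of modest size, if any, and most likely none beyond the scatter.

The step from compound 1 to compound 4 is expected to come out as a 1.5-fold higher number from compound 1 to compound 4 (0.17 log units; within the scatter). Compound 4 is estimated at 1500 nM in this assay, within a range from 500 nM to 4500 nM.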

Compound 4, half-maximal inhibitory concentration: 2030 nM
The estimate for compound 4 lay 1.4-fold (0.13 log units) below the measured number; measured number inside the range.
By their numbers in this assay, from the lowest: compounds 1 and 4 (each within the scatter of the next); then compound 2.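

In this assay, for the compounds shown here, the change from phenyl to 2-methylphenyl gives a 2.0-fold higher number from compound 1 to compound 4 (0.30 log units; within the scatter) and is the first comparison in this set that can be read at a single place. Going by these compounds alone, a methyl on an aromatic carbon, ortho to a large group, therefore leaves compound 4 within the scatter of compound 1, so this one added carbon produces no step that can be told apart from repeat measurement. No measured information bears on this result, and it offers no explanation for it.

Going by these compounds, it remains open whether a larger group at this place, such as ethyl or isopropyl, or one carrying other atoms, such as methoxy, an amine or a carboxylic acid, would also stay within the scatter, and whether the same methyl would behave alike on the other carbons of the phenyl ring. Compound 2 and compound 3 differ from compound 1 at more than one place, so their steps cannot be read, and the effect of fluorine on this ring stays unresolved.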